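Working notes on an amide series toward compound 4

A few compounds are considered here, and "the series" means these few. Any claim that something is new, unique, unknown or untested is made for them only; others in the source may bear on it.

Measured so far:
compound 1 `CCCn1c(NC(=O)c2cncn2C)nc2cc(C(N)=O)cc(OC)c21`: > 100000 nM
compound 2 `CCn1nc(C)cc1C(=O)Nc1nc2cc(C(=O)OC)cc(OC)c2n1CCCNC(=O)OCc1ccccc1`: 27600 nM
compound 3 `COc1cc(C(N)=O)cc2nc(NC(=O)c3ccc4ccccc4n3)n(CCCNC(=O)OCc3ccccc3)c12`: > 100000 nM

In an assay for activation of interferon regulatory factor 3 (Homo sapiens), read by a luciferase reporter, with a stated time of 20 h (on this read-out lower numbers stand for an effect already at smaller amounts and higher numbers for an effect only at larger amounts of compound), compound 1 gives > 100000 nM, a limit of the assay rather than a number. Compound 2 gives 27600 nM. Compound 3 likewise gives > 100000 nM, which is a limit and not a number. Among the compounds with values here, compound 3 therefore sits at the limit of > 100000 nM in this assay, at which 2 of the 3 values shown sit, the single true number in the set being that of compound 2.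

Compound 4 `COc1cc(C(N)=O)cc2nc(NC(=O)CCc3ccccc3)n(CCCNC(=O)OCc3ccccc3)c12` differs from compound 3 by phenethyl in place of quinolin-2-yl on a carbonyl carbon. Within the data shown here, no measured pair differs in one place, so no step size is known from the data; with compound 3 at a limit, no direction can be read off either, and compound 4 is expected to stay near that limit, the step of a number no higher from compound 3 to compound 4 (the limit leaves the size open) being within the scatter. Compound 4 is accordingly estimated at 100000 nM, in the range 30000 nM to 300000 nM.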

Compound 4, half-maximal effective concentration: > 100000 nM
Compound 4: no number, only a limit; the forecaster's own chance of this, stated with the estimate: 70%; the middle value sits exactly at the limit.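

Compound 3 and compound 4 both stand at limits rather than numbers, so the step between them cannot be read. Going by these compounds, whether phenethyl in place of quinolin-2-yl on a carbonyl carbon changes the read-out at all stays open.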